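A few compounds are considered here, and "the series" means these few. Any claim that something is new, unique, unknown or untested is made for them only; others in the source may bear on it.

Compound 1 `O=C1Nc2ccccc2/C1=N/NC(=S)Nc1ccccc1` sits at the strongest end of the three compounds that have been measured. In a functional assay on KB 3-1 cells (Homo sapiens) for cytotoxicity, read by MTT assay, with a stated time of 72 h (on this read-out higher numbers stand for weaker inhibition and lower numbers for stronger inhibition), compound 1 gives 3530 nM, the lowest of the three numbers. Compound 2 `CC(C)NC(=S)N/N=C1\C(=O)Nc2ccccc21` gives 39300 nM in this assay, and compound 3 `CNC(=S)N/N=C1\C(=O)Nc2ccccc21` gives 35300 nM. The two steps away from compound 1 are both clear: an 11-fold higher number from compound 1 to compound 2 (1.05 log units; beyond the scatter), and a 10-fold higher number from compound 1 to compound 3 (1.00 log units; beyond the scatter). Between the two smaller groups there is no real gap, since a 1.1-fold lower number from compound 2 to compound 3 (0.05 log units; within the scatter).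

Compound 4 `O=C1Nc2ccccc2/C1=N/NC(=S)Nc1ccc(C(=O)O)cc1` keeps the phenyl that compound 1 carries and changes it in one place: carboxy in place of hydrogen on an aromatic carbon. The measured steps all concern swapping the phenyl itself for a smaller group, and they show that the phenyl is worth keeping; none of them tests what happens when a group is added onto that phenyl. They therefore give no direct guide to the size or direction of this change, and the cautious expectation is a step close to the scatter, perhaps a little toward weaker inhibition. Compound 4 is expected to give about 5000 nM in this assay, within a range of 1500 nM to 16000 nM, which would mean a 1.4-fold higher number from compound 1 to compound 4 (0.15 log units; within the scatter).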

Compound 4, half-maximal inhibitory concentration: > 50000 nM
Compound 4 was reported as a limit (the forecaster's own chance of this, stated with the estimate: 5%); at least 10-fold (1.00 log units) between middle value and limit.
By their numbers in this assay, from the lowest: compound 1; then compounds 3 and 2 (each within the scatter of the next). At a limit, above all of these: compound 4.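

The earlier steps shown here all swapped the phenyl of compound 1 for a smaller group, whereas compound 4 keeps that phenyl and shows that a single addition onto it can matter just as much. In this assay, carboxy in place of hydrogen, on an aromatic carbon para to a large group, gives an at least 14-fold higher number from compound 1 to compound 4 (1.15 log units; beyond the scatter), a step at least as large as those seen on removing the phenyl altogether. Compound 4 is reported as a limit and not as a number, so this step marks only the least that the change costs, and its true size stays unknown: the limit of > 50000 nM in this assay, at which 1 of the 4 values shown sits.

What the compounds shown leave open is whether this loss belongs to carboxy in particular or would follow any addition at this carbon, a question that a methyl ester, an amine or a fluorine at the same place would help to settle. They also leave open whether carboxy placed elsewhere on the phenyl would give a similar result, and whether a smaller addition would be tolerated.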